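Aryl carbamoyl for ethylsulfonyl on the ring amine

A few compounds are considered here, and "the series" means these few. Any claim that something is new, unique, unknown or untested is made for them only; others in the source may bear on it.

Of the compounds shown here, three have been read in a functional assay on MDA-MB-231 cells (Homo sapiens) for antiproliferative activity, read by MTT assay, with a stated time of 48 h; on this read-out lower numbers stand for stronger inhibition and higher numbers for weaker inhibition. Compound 1 `C=CS(=O)(=O)N1CCN(c2ncnc3sc(-c4ccc(C(F)(F)F)cc4)cc23)CC1` gives 6410 nM in this assay. Compound 3 `CCS(=O)(=O)N1CCN(c2ncnc3sc(-c4ccc(N5CCN(C)CC5)cc4)cc23)CC1` gives 7330 nM in this assay, the higher of the two numbers, yet the gap to compound 1 lies within the scatter, so the two read alike. Compound 2 `C=CS(=O)(=O)N1CCN(c2nc(OC[C@H]3CCCN3C)nc3sccc23)CC1` reaches only a limit in this assay, > 50000 nM, and no number; (the limit of > 50000 nM in this assay, at which 1 of the 3 values shown sits).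

Compound 4 `CN1CCN(c2ccc(-c3cc4c(N5CCN(C(=O)Nc6cccc(F)c6)CC5)ncnc4s3)cc2)CC1` is not yet measured. It differs from compound 3 in one place: (3-fluorophenyl)carbamoyl in place of ethylsulfonyl on an amine nitrogen in a ring. The change sits on the amine nitrogen of the six-membered non-aromatic ring with two nitrogens, the ring bonds of the nitrogen and of the atom bearing the large group being unchanged.

Going by the values given here, no pair of measured compounds shows what such a change does, so the expectation rests on compound 3 alone. The step from compound 3 to compound 4 is expected to be small, toward a lower number, and not clearly beyond the scatter: a 1.8-fold lower number from compound 3 to compound 4 (0.26 log units; within the scatter). Compound 4 is therefore expected to give about 4000 nM in this assay, within 1000 nM to 20000 nM.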

Compound 4, half-maximal inhibitory concentration: 13200 nM
The estimate for compound 4 lay 3.3-fold (0.52 log units) below the measured number; the range from low to high includes it.
By their numbers in this assay, from the lowest: compounds 1, 3 and 4 (each within the scatter of the next, the first and the last beyond it). At a limit, above all of these: compound 2.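

In this assay, (3-fluorophenyl)carbamoyl in place of ethylsulfonyl on the amine nitrogen in the ring gives a 1.8-fold higher number from compound 3 to compound 4 (0.26 log units; within the scatter), the first step read at this position. On this single pair, a much larger group with a carbon-only aromatic ring and a hydrogen-bond donor, which ethylsulfonyl lacks, is not separated from ethylsulfonyl by this read-out. Nothing measured on record accounts for the result.

From the compounds shown here alone, it remains open whether the fluorine contributes anything, which an unsubstituted phenylcarbamoyl or a 4-fluorophenylcarbamoyl on the same nitrogen would test. Also open, going by these compounds, is whether a smaller acetyl group or a chain ending in a tertiary amine at this nitrogen would move the number beyond the scatter, and whether the flat response holds with other groups on the core.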